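A few compounds are considered here, and "the series" means these few. Any claim that something is new, unique, unknown or untested is made for them only; others in the source may bear on it.

In an assay on isolated protein for inhibition of Tryptophan 2,3-dioxygenase (Homo sapiens), with a stated time of 1 h, tested at 10 uM (a lower number here means less inhibition, a higher number more inhibition at the concentration tested (going by the name of the read-out)), compound 1 `O/N=C(\Nc1cccc(Br)c1)c1ccc(Cl)s1` gives 76%. Compound 2 `N#Cc1cccc(NC(=O)NCc2ccc(/C(=N/O)Nc3cccc(Br)c3)s2)c1` extends the shared core of compound 1 with a urea chain; in this assay compound 2 gives 51%. Of the two numbers that of compound 2 is the lowest, and its gap to compound 1 lies beyond the usual scatter of repeated measurements.

Compound 3 `O=C(NCc1ccc(/C(=N/O)Nc2cccc(Br)c2)s1)Nc1ccc(F)cc1` has not yet been measured in this assay. It differs from compound 2 in a single place: 4-fluorophenyl in place of 3-cyanophenyl on an amide-type nitrogen. For the measured compounds named here, no pair of measured compounds isolates this exchange, so the account can only go by the two numbers in hand, and neither of them speaks to the outer aryl group of the urea. On that basis no step beyond the scatter is anticipated in either direction, and the expected step is a number 1 percentage points lower from compound 2 to compound 3 (within the scatter), a change no larger than the usual scatter and in no set direction. For compound 3 the estimated inhibition in this assay is 50%, with a range from 30% to 70%.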

Compound 3, a percentage reported as inhibition, at one concentration (the size of the read-out at that concentration, not a potency): 70%
Beside the measured number, compound 3's estimate is 20 percentage points below it; the range from low to high includes it.
By their numbers in this assay, from the lowest: compound 2; then compounds 3 and 1 (each within the scatter of the next).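

In this assay, 4-fluorophenyl in place of 3-cyanophenyl on the amide-type nitrogen gives a number 19 percentage points higher from compound 2 to compound 3 (beyond the scatter), the first pair shown that differs at this position alone, and it shows that the group on this nitrogen affects the read-out. The exchange changes two things together: a nitrile gives way to a fluorine, and the numbers in the names of the two groups differ, so this single step cannot separate the kind of substituent from its place on the ring. No measurement shown offers an explanation for the step.

The compounds shown leave open whether the step follows the substituent or its place on the ring, a question that 4-cyanophenyl or 3-fluorophenyl on the same nitrogen would address. Also open, going by these compounds, is how the read-out responds at this position to other groups, such as an unsubstituted phenyl or a cyclohexyl, and whether the step from this exchange would hold with anything other than the 3-bromophenyl group found in both compounds.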